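Hydroxy for methyl on the benzyl ring of compound 3

The source may report more compounds than this note shows. Statements on the series, on what has been measured and on what is new or still open speak of the compounds shown alone.

Compound 3 `COc1ccc(CN(C(=O)CSc2nc3ccccc3s2)c2cc(OC)c(OC)c(OC)c2)cc1C` gives 17100 nM in a functional assay on HCT-116 cells (Homo sapiens) for antiproliferative activity, read by MTT assay, with a stated time of 48 h (on this read-out higher numbers stand for weaker inhibition and lower numbers for stronger inhibition), the highest of the three numbers in hand; compound 2 `COc1ccc(CN(C(=O)CSc2nc3ccccc3s2)c2cc(OC)c(OC)c(OC)c2)cc1F` gives 1830 nM and compound 1 `COc1ccc2nc(SCC(=O)N(Cc3ccc(OC)c(O)c3)c3cc(OC)c(OC)c(OC)c3)sc2c1` gives 352 nM. Compound 4 `COc1ccc(CN(C(=O)CSc2nc3ccccc3s2)c2cc(OC)c(OC)c(OC)c2)cc1O` differs from compound 3 by hydroxy in place of methyl on an aromatic carbon. Within the data shown here, the only step at this position is a 9.3-fold higher number from compound 2 to compound 3 (0.97 log units; beyond the scatter), and compound 1, which carries the same hydroxy beside a further methoxy on its core, gives 352 nM, whereas compound 3 gives 17100 nM. Both point to a lower number for the hydroxy; the step is expected to be a 19-fold lower number from compound 3 to compound 4 (1.28 log units; beyond the scatter). Compound 4 is therefore estimated at 900 nM, with a range from 250 nM to 4000 nM.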

Compound 4, half-maximal inhibitory concentration: 182 nM
Compound 4: the middle estimate sits 4.9-fold (0.69 log units) above what was measured, outside the stated range (below it).
By their numbers in this assay, from the lowest: compounds 4 and 1 (each within the scatter of the next); then compound 2; then compound 3.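

In this assay, hydroxy on this aromatic carbon gives a 94-fold lower number from compound 3 to compound 4 (1.97 log units; beyond the scatter) against methyl and a 10-fold lower number from compound 2 to compound 4 (1.00 log units; beyond the scatter) against fluoro, so the three groups now rank hydroxy, fluoro, methyl, with every step beyond the scatter. The further methoxy on the core of compound 1 adds no readable difference: a 1.9-fold lower number from compound 1 to compound 4 (0.29 log units; within the scatter) lies within the scatter. No measurement here explains the effect of the hydroxy. As far as these compounds go, whether an amine or a carboxylic acid on this carbon would match the hydroxy stays open.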